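Shortening the alkynyl chain of a deoxyuridine analogue

The source may hold more compounds than are shown below. What is called first, only, known or untested is meant among the compounds shown, and "the series" means these compounds.

Compound 1 `CC(C)(C)C#Cc1cn([C@H]2C[C@H](O)[C@@H](CO)O2)c(=O)[nH]c1=O` and compound 2 `CCCCCC#Cc1cn([C@H]2C[C@H](O)[C@@H](CO)O2)c(=O)[nH]c1=O` share one core and differ only in the group on the triple-bonded carbon. In a functional assay on L1210 cells (Mus musculus) (on this read-out lower numbers stand for stronger inhibition and higher numbers for weaker inhibition), compound 1 gives 287 ug/mL and compound 2 gives 219 ug/mL, the step between them being a 1.3-fold lower number from compound 1 to compound 2 (0.12 log units; within the scatter). Compound 2 thus stands at the lower of the two numbers, but its gap to compound 1 lies within the scatter. Compound 3 `CCCC#Cc1cn([C@H]2C[C@H](O)[C@@H](CO)O2)c(=O)[nH]c1=O` differs from compound 2 as follows: hydrogen in place of ethyl on a saturated chain carbon, three bonds along the chain from a triple-bonded carbon. Among the compounds with values here, no measured step shortens this chain directly; the only step at hand, a 1.3-fold lower number from compound 1 to compound 2 (0.12 log units; within the scatter), stayed within the scatter, so the loss of ethyl from the chain is expected to leave the number within the scatter as well, in no clear direction. Compound 3 is therefore estimated at 240 ug/mL, with a range from 120 ug/mL to 480 ug/mL. The expected step is a 1.1-fold higher number from compound 2 to compound 3 (0.04 log units; within the scatter).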

Compound 3, concentration for 50% inhibition: > 1000 ug/mL
Compound 3: only a limit was reported (the forecaster's own chance of this, stated with the estimate: 5%); middle value at least 4.1-fold (0.61 log units) from the limit.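

In this assay compound 3 gives > 1000 ug/mL, which is a limit of the assay and not a number. The group on the triple-bonded carbon is therefore not free to vary: tert-butyl and pentyl had stayed within the scatter of each other, whereas propyl gives an at least 4.5-fold higher number from compound 2 to compound 3 (0.65 log units; beyond the scatter) and an at least 3.4-fold higher number from compound 1 to compound 3 (0.54 log units; beyond the scatter). Losing ethyl from the pentyl chain thus weakens inhibition clearly, so a change at this position can register on this read-out even though the first step did not.

From the compounds shown here alone, how large the two steps really are stays open, since neither has an upper bound: the limit of > 1000 ug/mL in this assay, at which 1 of the 3 values shown sits. Also open is how a longer chain such as heptyl, or an amine or a hydroxyl at the end of the pentyl chain, would stand against compound 2.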